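Hydrazone aryl swap: pyridin-4-yl for 2,4-dimethoxyphenyl

The source may hold more compounds than are shown below. What is called first, only, known or untested is meant among the compounds shown, and "the series" means these compounds.

Measured so far in a functional assay on the whole organism (strain Wistar) for inhibition, with Rattus norvegicus as the target, read by paw edema, with a stated time of 1 h, at a dose of 10 mg/kg by the intraperitoneal route; a higher number here means more inhibition at the dose given (going by the name of the read-out), a lower number less inhibition:
compound 1 `O=C(N/N=C/c1ccc(O)c(O)c1)c1cccnc1Nc1cccc(C(F)(F)F)c1` gives 50.8%.
compound 2 `COc1ccc(/C=N/NC(=O)c2cccnc2Nc2cccc(C(F)(F)F)c2)c(OC)c1` gives 55.7%.

Compound 2 holds the higher of the two numbers, but its margin over compound 1 is a number 4.9 percentage points higher from compound 1 to compound 2 (within the scatter), so the two cannot be ordered.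

Compound 3 `O=C(N/N=C/c1ccncc1)c1cccnc1Nc1cccc(C(F)(F)F)c1` is not yet measured. Its change from compound 2 is pyridin-4-yl in place of 2,4-dimethoxyphenyl on a carbon with a double bond to nitrogen. Among the compounds with values here, the only step at hand that touches this position is the one from compound 1 to compound 2, a number 4.9 percentage points higher from compound 1 to compound 2 (within the scatter), which stayed within the scatter although it swapped hydroxy groups for methoxy groups on the same ring. Within the data shown here, no step has exchanged the carbocyclic ring for a heteroaromatic one, so there is no direct precedent for the pyridin-4-yl group.

Given that the one relevant step was flat, compound 3 is expected to give a step of a number 5.7 percentage points lower from compound 2 to compound 3 (within the scatter) in this assay, that is, nothing beyond the scatter. The estimate for compound 3 is 50%, with a range from 35% to 65%.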

Compound 3, a percentage reported as inhibition, in the whole organism at one dose (the size of the read-out at that dose, not a potency): 70.2%
For compound 3 the middle estimate is 20.2 percentage points below the measured one; measured number outside the range, above it.
By their numbers in this assay, from the lowest: compounds 1 and 2 (each within the scatter of the next); then compound 3.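

In this assay the group on the carbon with a double bond to nitrogen can move the read-out beyond the scatter, as shown by a number 14.5 percentage points higher from compound 2 to compound 3 (beyond the scatter) and by a number 19.4 percentage points higher from compound 1 to compound 3 (beyond the scatter) in the same series. Within the data shown here, the only earlier step at this position, a number 4.9 percentage points higher from compound 1 to compound 2 (within the scatter) between two substituted phenyl groups, gave no sign of this, so the position is not indifferent to the choice of aromatic ring. No supporting measurement bears on why pyridin-4-yl gives this result.

Whether the ring nitrogen itself accounts for the step stays open, and an unsubstituted phenyl or a pyridin-3-yl group at this place would test that directly. On these data alone, these numbers also describe one dose at one stated time, so they give the size of the effect rather than a potency, and the order at other doses remains unknown.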